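Thiophene Replaces Pyridine in HDAC6 Hydroxamate Series

A few compounds are considered here, and "the series" means these few. Any claim that something is new, unique, unknown or untested is made for them only; others in the source may bear on it.

Measured compounds:
compound 1 `Cc1ccc(-c2nc(CNc3ccc(C(=O)NO)cc3)n(-c3ccccc3)n2)cc1`, 62.2%
compound 2 `O=C(NO)c1ccc(NCc2nc(-c3ccccc3)nn2-c2ccccc2)cc1`, 72.6%
compound 3 `O=C(NO)c1ccc(NCc2nc(-c3ccccn3)nn2-c2ccccc2)cc1`, 58.6%

In an assay on Sf9 cells for inhibition of protein deacetylase HDAC6 (Homo sapiens), read by fluorescence, with a stated time of 40 min, tested at 100 nM (a lower number here means less inhibition, a higher number more inhibition at the concentration tested (going by the name of the read-out)), compound 3 gives the lowest of the three numbers: compound 1 lies nearby, within the scatter, while compound 2 lies further off, a number 14 percentage points lower from compound 2 to compound 3 (beyond the scatter). Compound 4 `O=C(NO)c1ccc(NCc2nc(-c3ccsc3)nn2-c2ccccc2)cc1` differs from compound 3 by thiophen-3-yl in place of pyridin-2-yl on an aromatic carbon. Going by the values given here, the steps that bear on this change are a number 14 percentage points lower from compound 2 to compound 3 (beyond the scatter) and a number 3.6 percentage points lower from compound 1 to compound 3 (within the scatter), so swapping the group on that carbon has so far moved this assay by a modest amount at most. For compound 4 a small upward step is expected, a number 5.4 percentage points higher from compound 3 to compound 4 (within the scatter), close to the scatter. Compound 4 is therefore estimated at 64%, between 50% and 78%.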

Compound 4, a percentage reported as inhibition, at one concentration (the size of the read-out at that concentration, not a potency): 53.4%
For compound 4 the middle estimate is 10.6 percentage points above the measured one; measured number inside the range.
By their numbers in this assay, from the lowest: compounds 4, 3 and 1 (each within the scatter of the next); then compound 2.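

In this assay the five-membered thiophen-3-yl ring reads alike with the six-membered pyridin-2-yl (a number 5.2 percentage points lower from compound 3 to compound 4 (within the scatter)) and 4-methylphenyl (a number 8.8 percentage points lower from compound 1 to compound 4 (within the scatter)), so ring size does not separate these compounds. Only phenyl stands apart on this carbon (a number 19.2 percentage points lower from compound 2 to compound 4 (beyond the scatter)), and all three replacements shown give lower numbers than it does. Nothing measured here explains this. From the compounds shown here alone, whether an amine or a cyclohexyl ring on this carbon would match compound 2 remains open.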